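Adding a Methoxybenzyl Group on a Ring Nitrogen

The source may hold more compounds than are shown below. What is called first, only, known or untested is meant among the compounds shown, and "the series" means these compounds.

Measured compounds:
Compound 1, `COc1cc(Nc2nc(C(=N)Nc3ccc(N4CCN(C)CC4)cc3)cc3c(-c4ccccc4)n[nH]c23)cc(OC)c1OC`: 4300 nM in a functional assay on PC-3 cells (Homo sapiens) for cytotoxicity, read by MTT assay, with a stated time of 72 h; a lower number here means a stronger inhibitor, a higher number a weaker inhibitor
Compound 2, `COc1cc(Nc2nc(C(=N)Nc3ccccc3)cc3c(-c4ccccc4)n[nH]c23)cc(OC)c1OC`: 5800 nM in this assay
Compound 3, `COc1ccc(Cn2cc3cc(C(=N)Nc4cccc(C(F)(F)F)c4)ncc3n2)cc1`: 12800 nM in this assay

Among these three, compound 1 gives the lowest number in this assay. Its nearest neighbour is compound 2, reached by replacing 4-methylpiperazin-1-yl with hydrogen on an aromatic carbon, a change that gave a 1.3-fold higher number from compound 1 to compound 2 (0.13 log units; within the scatter). Compound 3, built on a different core, gives a higher number than compound 1, but no single change separates the two, so only their two values can be compared.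

Compound 4, `COc1ccc(Cn2nc(-c3ccccc3)c3cc(C(=N)Nc4ccc(N5CCN(C)CC5)cc4)nc(Nc4cc(OC)c(OC)c(OC)c4)c32)cc1`, is compound 1 with one alteration: 4-methoxybenzyl in place of hydrogen on an aromatic nitrogen. Among the compounds with values here, no measured step matches this change. Within the data shown here, the only measured step, from compound 1 to compound 2, concerns a different position and lies within the scatter, so it offers no guide to size or direction. Compound 3 carries the same 4-methoxybenzyl group on a ring nitrogen, yet its many other differences from compound 1 mean its higher value cannot be read as the effect of that group.

Among the measured compounds shown here, with no step of this kind to lean on, compound 4 is expected to stay close to compound 1, the estimated step being a 1.4-fold higher number from compound 1 to compound 4 (0.14 log units; within the scatter). The estimate for compound 4 is therefore 6000 nM, within a range from 2500 nM to 15000 nM.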

Compound 4, half-maximal inhibitory concentration: 1240 nM
Compound 4: the middle estimate sits 4.8-fold (0.68 log units) above what was measured; the whole stated range lies above it.
By their numbers in this assay, from the lowest: compound 4; then compounds 1 and 2 (each within the scatter of the next); then compound 3.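

Within the data shown here, this nitrogen on the shared core is the first place where a single change moves the number beyond the scatter: in this assay, putting 4-methoxybenzyl in place of the hydrogen gave a 3.5-fold lower number from compound 1 to compound 4 (0.54 log units; beyond the scatter) on this core. Among these compounds, the only earlier step, a 1.3-fold higher number from compound 1 to compound 2 (0.13 log units; within the scatter) at a different position, stayed within the scatter, and compound 3 differed from compound 1 in too many places to show what this group does, so this is the first direct reading of the change. Nothing given here explains why the number falls with this change.

The step also does two things at once, removing the hydrogen from the ring nitrogen and adding 4-methoxybenzyl, so a single pair cannot tell which part matters, or whether the methoxy group on the benzyl ring contributes at all. A plain benzyl group, a methyl group or a longer chain ending in an amine on this nitrogen would help separate these, and the same 4-methoxybenzyl group on compound 2 would show whether the step carries over without 4-methylpiperazin-1-yl.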